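Hydrogen for chloro in a series at the assay limit

This account rests on a few compounds, and the source may have more. Where it says the series, first, only, none or still open, it means among the compounds named here.

In a toxicity assay on NIH3T3 cells (Mus musculus) for cytotoxicity, read by resazurin assay (on this read-out higher numbers stand for an effect only at larger amounts of compound and lower numbers for an effect already at smaller amounts), compound 1 `Clc1ccc(NCc2cncn2Cc2ccc(-c3ccccc3)cc2)cc1-c1ccccc1` gives a limit and not a number (> 1000 nM). Compound 2 `Nc1cc(-c2ccccc2)ccc1Cn1cncc1CNc1ccc(Cl)c(-c2ccccc2)c1` also gives only a limit (> 1000 nM). Compound 3 `CNC(=O)c1ccc(NCc2cncn2Cc2ccc(-c3ccccc3)cc2N)cc1-c1ccccc1` likewise gives only a limit (> 1000 nM). The whole set therefore offers one shared reading: the limit of > 1000 nM in this assay, at which 3 of the 3 values shown sit.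

Compound 4 `c1ccc(-c2ccc(Cn3cncc3CNc3cccc(-c4ccccc4)c3)cc2)cc1` has not yet been measured. It differs from compound 1 by hydrogen in place of chloro on an aromatic carbon, ortho to a phenyl group: hydrogen in place of chloro on an aromatic carbon.

Within the data shown here, two measured steps bear on this change. One also removes the chloro, putting methylcarbamoyl in its place, and it is a step that the two limits leave unreadable from compound 2 to compound 3. The other puts amino in place of hydrogen on an aromatic carbon, and it is a step that the two limits leave unreadable from compound 1 to compound 2. Neither step has a size that can be read, so they offer no sign of a shift in either direction. No step beyond the scatter is expected in this assay, and the most likely outcome is another limit.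

The expected step is a step that the limit leaves unreadable from compound 1 to compound 4. If a number is obtained, the estimate for compound 4 is 3000 nM, with an expected range from 800 nM to 10000 nM.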

Compound 4, half-maximal effective concentration: 10000 nM
Estimate against measurement, compound 4: 3.3-fold (0.52 log units) below, within the range that was stated.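

In this assay compound 4 gives 10000 nM. Among these compounds, compound 1 gives only a limit, > 1000 nM, so no step from compound 1 to compound 4 can be read. The compounds shown leave open the size and direction of any shift from hydrogen in place of chloro: no pair differing in one place has numbers on both sides.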